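Halogen Swap on the Anilino Ring of Compound 3

A few compounds are considered here, and "the series" means these few. Any claim that something is new, unique, unknown or untested is made for them only; others in the source may bear on it.

Of the compounds shown here, three built on one shared core have been measured in a functional assay on MGC-803 cells (Homo sapiens) for inhibition, read by MTT assay, with a stated time of 72 h; a higher number here means a weaker inhibitor, a lower number a stronger inhibitor. Compound 1 `C=CC(=O)Nc1cccc(NC(=O)CSc2nc(Nc3cccc(Cl)c3)c3ccccc3n2)c1` gives 7830 nM in this assay. Compound 2 `C=CC(=O)Nc1cccc(NC(=O)CSc2nc(Nc3cccc(Br)c3)c3ccccc3n2)c1` gives 11900 nM in this assay. Compound 3 `C=CC(=O)Nc1cccc(NC(=O)CSc2nc(Nc3ccc(Cl)cc3)c3ccccc3n2)c1` gives 14300 nM in this assay. Compound 2 differs from compound 1 by bromo in place of chloro on an aromatic carbon, and that step is a 1.5-fold higher number from compound 1 to compound 2 (0.18 log units; within the scatter). Compound 3 differs from compound 1 by 4-chlorophenyl in place of 3-chlorophenyl on a nitrogen on an aromatic ring, a step of a 1.8-fold higher number from compound 1 to compound 3 (0.26 log units; within the scatter). The step between the remaining pair is a 1.2-fold higher number from compound 2 to compound 3 (0.08 log units; within the scatter). All three numbers therefore lie within the scatter of one another, and no order among them can be claimed.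

Compound 4 `C=CC(=O)Nc1cccc(NC(=O)CSc2nc(Nc3ccc(Br)cc3)c3ccccc3n2)c1` has not yet been measured. It differs from compound 3 by bromo in place of chloro on an aromatic carbon. This is the same kind of change as that from compound 1 to compound 2, but not the same: in the earlier pair the halogen sits meta to a large group, whereas here it sits para to a large group. Because the earlier step was a 1.5-fold higher number from compound 1 to compound 2 (0.18 log units; within the scatter), the step expected for compound 4 is a 1.3-fold higher number from compound 3 to compound 4 (0.12 log units; within the scatter) in this assay. Compound 4 is estimated at 19000 nM in this assay, with a likely range from 9000 nM to 40000 nM. Only two examples of this change exist among these compounds, so the expectation rests on a single measured pair.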

Compound 4, half-maximal inhibitory concentration: 11500 nM
Beside the measured number, compound 4's estimate is 1.7-fold (0.22 log units) above it; the measured number falls inside the stated range.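

In this assay, bromo in place of chloro on an aromatic carbon, para to a large group, gives a 1.2-fold lower number from compound 3 to compound 4 (0.09 log units; within the scatter), and the two other steps reaching compound 4, a 1.0-fold lower number from compound 2 to compound 4 (0.01 log units; within the scatter) and a 1.5-fold higher number from compound 1 to compound 4 (0.17 log units; within the scatter), are just as small. Set beside the same change where the halogen sits meta to a large group, the new step does not differ from the earlier one: the same change on two cores in this assay, a 1.5-fold higher number (0.18 log units; within the scatter) from compound 1 to compound 2 and a 1.2-fold lower number (0.09 log units; within the scatter) from compound 3 to compound 4, 1.9-fold (0.28 log units) apart, within the scatter of two such steps. This shows that the change stays within the scatter in both of the measured pairs, so these four compounds give no sign that it behaves differently from one setting to the other, but it does not show that the change has any real effect in either setting, and the opposite directions of the two steps carry no meaning.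

The compounds shown carry only chloro or bromo on the anilino ring, so they leave open whether a different group there, such as a methoxy, a nitrile or an amine, would move the number beyond the scatter. They also leave open whether the number depends on the acrylamide, for instance if a saturated propanamide stood in its place.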